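The compounds below may be only part of what the source reports. "The series", "measured", "known", "first", "only" and "open" are said of these compounds alone.

Measured so far in a functional assay on SW-620 cells (Homo sapiens) for inhibition, read by MTT assay, with a stated time of 72 h; on this read-out higher numbers stand for weaker inhibition and lower numbers for stronger inhibition:
compound 1 `O=c1cc(Cn2cc(C3CC3)nn2)c2ccc(O)cc2o1`: > 100000 nM.
compound 2 `O=c1cc(Cn2cc(CCCCO)nn2)c2ccc(O)cc2o1`: > 100000 nM.
compound 3 `O=c1cc(Cn2cc(-c3cc(F)cc(F)c3)nn2)c2ccc(O)cc2o1`: 66700 nM.

Compound 1 gives in this assay only a limit, not a number: the limit of > 100000 nM in this assay, at which 2 of the 3 values shown sit. Compound 2 likewise returns only a limit, so the step that the two limits leave unreadable from compound 1 to compound 2 stays unreadable. Among the compounds with values here, the one readable step, an at least 1.4-fold lower number from compound 1 to compound 3 (0.17 log units; that floor lies within the scatter), carries an aromatic ring in place of the cyclopropyl, and this is the step that bears on compound 4 `O=c1cc(Cn2cc(-c3ccc(Br)cc3)nn2)c2ccc(O)cc2o1`, which differs from compound 1 by 4-bromophenyl in place of cyclopropyl on an aromatic carbon. A step of similar size and direction is expected, an at least 1.6-fold lower number from compound 1 to compound 4 (0.22 log units; that floor lies within the scatter), with a real chance that only a limit is returned again. Compound 4 is therefore estimated at 60000 nM, within 25000 nM to 150000 nM.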

Compound 4, half-maximal inhibitory concentration: 97700 nM
Estimate against measurement, compound 4: 1.6-fold (0.21 log units) below; measured number inside the range.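

In this assay, compound 4 sits with compound 3 as a second aromatic substituent on this carbon of the five-membered ring, and a 1.5-fold higher number from compound 3 to compound 4 (0.17 log units; within the scatter), so 3,5-difluorophenyl and 4-bromophenyl cannot be ordered. Against the non-aromatic groups only floors can be read, an at least 1.0-fold lower number from compound 1 to compound 4 (0.01 log units; that floor lies within the scatter) and an at least 1.0-fold lower number from compound 2 to compound 4 (0.01 log units; that floor lies within the scatter), so no gain from 4-bromophenyl is shown. Compound 1 and compound 2 remain limits: the limit of > 100000 nM in this assay, at which 2 of the 4 values shown sit.

Open, on these data alone, is whether an amine or a carboxylic acid at this place would move the number beyond the scatter.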